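Anilino-quinazolines against U-937 cells: a hydroxyphenyl variant

The source may report more compounds than this note shows. Statements on the series, on what has been measured and on what is new or still open speak of the compounds shown alone.

Measured compounds and values:
compound 1, `Fc1cccc(-c2nc(Nc3ccccc3)c3cc(F)ccc3n2)c1`, 45500 nM
compound 2, `COc1ccc(Nc2nc(-c3cccc(F)c3)nc3ccc(F)cc23)cc1`, 41100 nM
compound 3, `Fc1cccc(-c2nc(Nc3cccc(Br)c3)c3cc(F)ccc3n2)c1`, > 50000 nM

The three compounds share one core and differ only in the ring attached to the nitrogen on the aromatic ring. In a functional assay on U-937 cells (Homo sapiens) for cytotoxicity, read by MTT assay, with a stated time of 48 h (on this read-out lower numbers stand for stronger inhibition and higher numbers for weaker inhibition), compound 1 gives 45500 nM and compound 2 gives 41100 nM. For compound 3 the assay reports only a limit, > 50000 nM, so compound 3 stands at the limit of > 50000 nM in this assay, at which 1 of the 3 values shown sits, and its exact number is not known. The steps among the measured compounds are all small: a 1.1-fold lower number from compound 1 to compound 2 (0.04 log units; within the scatter), an at least 1.0-fold higher number from compound 1 to compound 3 (0.04 log units; that floor lies within the scatter) and an at least 1.2-fold higher number from compound 2 to compound 3 (0.08 log units; that floor lies within the scatter).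

Compound 4, `Oc1ccccc1Nc1nc(-c2cccc(F)c2)nc2ccc(F)cc12`, has not been measured. It differs from compound 3 in that (2-hydroxyphenyl in place of 3-bromophenyl on a nitrogen on an aromatic ring). The step that bears on it most is an at least 1.2-fold higher number from compound 2 to compound 3 (0.08 log units; that floor lies within the scatter), an exchange of the same ring, and together with a 1.1-fold lower number from compound 1 to compound 2 (0.04 log units; within the scatter) it suggests that changes on this ring move the read-out little. Compound 4 is therefore expected to stay near the range of the measured compounds, with an at least 1.1-fold lower number from compound 3 to compound 4 (0.04 log units; that floor lies within the scatter), and its estimated value in this assay is 45000 nM, between 22000 nM and 100000 nM.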

Compound 4, half-maximal inhibitory concentration: 46300 nM
Compound 4: the middle estimate sits 1.0-fold (0.01 log units) below what was measured; the measured number falls inside the stated range.
By their numbers in this assay, from the lowest: compounds 2, 1 and 4 (each within the scatter of the next). At a limit, above all of these: compound 3.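

In this assay, 2-hydroxyphenyl is the first group shown on this nitrogen whose ring carries a hydrogen-bond donor, yet the read-out does not separate from the earlier compounds: the steps are a 1.0-fold higher number from compound 1 to compound 4 (0.01 log units; within the scatter) and a 1.1-fold higher number from compound 2 to compound 4 (0.05 log units; within the scatter). The comparison with compound 3 yields only a floor, an at least 1.0-fold lower number from compound 3 to compound 4 (0.03 log units; that floor lies within the scatter). Compound 3 is known here only as a limit: the limit of > 50000 nM in this assay, at which 1 of the 4 values shown sits.

The compounds shown leave open whether any group on this ring can move the number beyond the scatter, and what an amine or a carboxylic acid in place of the hydroxy would do. They also leave open whether a change elsewhere on the shared core, such as at the fluoro groups, would matter more than this exchange.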